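This account rests on a few compounds, and the source may have more. Where it says the series, first, only, none or still open, it means among the compounds named here.

Compound 1 `CN(C)C(=O)c1cccc(NC(=O)c2cc(Cl)ccc2O)c1` carries a dimethylcarbamoyl group on its core. Among the measured compounds shown here, in an ADME assay for permeability, using PAMPA (a higher number here means that the compound crosses the layer faster, a lower number that the compound crosses the layer more slowly), compound 1 gives 5 10^-6 cm/s, the only plain number so far. In this assay compound 2 `O=C(Nc1ccc(Cl)cc1Cl)c1cc(Cl)ccc1O` gives < 22.4 10^-6 cm/s, which is a limit of the assay and not a number. Compound 3 `COc1cccc(NC(=O)c2cc(Cl)ccc2O)c1` keeps the core of compound 1 but has methoxy in place of dimethylcarbamoyl on an aromatic carbon. For the measured compounds named here, no pair of measured compounds yet shows what such an exchange does, so this expectation rests on the structural change alone and remains uncertain. A rise in this assay beyond the usual scatter is expected. The estimated size of this move is a 2.8-fold higher number from compound 1 to compound 3 (0.45 log units; beyond the scatter). The estimate for compound 3 is 14 10^-6 cm/s, with an expected range from 6 10^-6 cm/s to 30 10^-6 cm/s.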

Compound 3, apparent permeability in the ADME assay: 43 10^-6 cm/s
Estimate against measurement, compound 3: 3.1-fold (0.49 log units) below; measured number outside the range, above it.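

In the ADME assay the exchange of dimethylcarbamoyl for methoxy on this aromatic carbon brings an 8.6-fold higher number from compound 1 to compound 3 (0.93 log units; beyond the scatter) and so gives this change its first measured size. In a physicochemical assay for solubility (a lower number here means a less soluble compound, a higher number a more soluble compound), the same exchange runs the other way, with an at least 20-fold lower number from compound 1 to compound 3 (1.31 log units; beyond the scatter) as its step, so at this position the gain in one read-out comes with a loss in the other. In the physicochemical assay compound 1 gives > 47 ug/mL as its value, which is a limit of the assay and not a number. In the physicochemical assay compound 3 gives 2.3 ug/mL.

A single exchange cannot say whether another group on this carbon, such as an amine, a carboxylic acid or a longer ether chain, would fall between compound 1 and compound 3 in both assays. It also leaves open whether the same exchange would act alike on a different core.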